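A Sulfonyl Exchange on Compound 3

The compounds below may be only part of what the source reports. "The series", "measured", "known", "first", "only" and "open" are said of these compounds alone.

In a functional assay on A549 cells (Homo sapiens) for antiproliferative activity, read by MTT assay, with a stated time of 24 h (a higher number here means a weaker inhibitor, a lower number a stronger inhibitor), compound 1 `Cc1ccc(-c2nn(-c3ccccc3)cc2-c2nc3ccccc3n2S(=O)(=O)c2cc(C)ccc2C)cc1` gives 270 nM, compound 2 `Cc1ccc(C)c(S(=O)(=O)n2c(-c3cn(-c4ccccc4)nc3-c3ccc(F)cc3)nc3ccccc32)c1` gives 200 nM and compound 3 `COc1ccc(S(=O)(=O)n2c(-c3cn(-c4ccccc4)nc3-c3ccc(C(F)(F)F)cc3)nc3ccccc32)cc1` gives 170 nM. Compound 3 therefore stands together with the other two, since all three values lie within the scatter of one another.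

Compound 4 `Cc1ccc(C)c(S(=O)(=O)n2c(-c3cn(-c4ccccc4)nc3-c3ccc(C(F)(F)F)cc3)nc3ccccc32)c1` differs from compound 3 in one place: 2,5-dimethylphenyl in place of 4-methoxyphenyl on a sulfonyl sulfur. The change is 2,5-dimethylphenyl in place of 4-methoxyphenyl on a sulfonyl sulfur. Within the data shown here, no measured step makes this exchange. Among the measured compounds shown here, the only step available, a 1.4-fold lower number from compound 1 to compound 2 (0.13 log units; within the scatter), concerns a different part of the molecule, and both of its compounds carry the entering 2,5-dimethylphenyl. That step stays within the scatter, so it offers only indirect guidance.

In this assay, no shift beyond the scatter is therefore expected, and the estimated step is a 1.1-fold higher number from compound 3 to compound 4 (0.05 log units; within the scatter). Compound 4 is estimated at 190 nM, with an expected range of 100 nM to 340 nM.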

Compound 4, half-maximal inhibitory concentration: 150 nM
Estimate against measurement, compound 4: 1.3-fold (0.10 log units) above; low and high end bracket the measured number.
By their numbers in this assay, from the lowest: compounds 4, 3, 2 and 1 (each within the scatter of the next).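

At the sulfonyl sulfur, this assay now gives a direct reading of this exchange: 2,5-dimethylphenyl in place of 4-methoxyphenyl gives a 1.1-fold lower number from compound 3 to compound 4 (0.05 log units; within the scatter) and so stays within the scatter, though the entering group has no oxygen and no hydrogen-bond acceptor. With 2,5-dimethylphenyl held constant, trifluoromethyl in place of fluoro gives a 1.3-fold lower number from compound 2 to compound 4 (0.12 log units; within the scatter) and trifluoromethyl in place of methyl gives a 1.8-fold lower number from compound 1 to compound 4 (0.26 log units; within the scatter) and neither exchange leaves the scatter. No other measurement bears on this result, so these readings remain without an explanation.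

Only two groups are shown on the sulfonyl sulfur, each with one six-membered aromatic ring of carbon only, so it remains open how a longer alkyl chain or a ring bearing an amine would read there. From the compounds shown here alone, the 4-methoxyphenyl group appears only in compound 3, so whether this exchange stays as small with fluoro or methyl in place of trifluoromethyl also remains open.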